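The source may hold more compounds than are shown below. What is called first, only, known or untested is meant among the compounds shown, and "the series" means these compounds.

Compound 1 `CNC(=O)c1cc(C(=O)NC2CC2)cc2c1O[C@H](CF)[C@H]2c1ccccc1` gives 3.9 in a physicochemical assay for lipophilicity, at pH 7.4 (a lower number here means a more polar compound, a higher number a more lipophilic compound), the second highest of the three numbers measured. Compound 3 `CNC(=O)c1cc(C(=O)NC2CC2)cc2c1OC[C@H]2c1ccccc1` gives 3.6. Going by the values given here, the only single-place step measured is a number 0.30 log units lower from compound 1 to compound 3 (within the scatter). Compound 2 `CNC(=O)c1cc(C(=O)N[C@H]2C[C@@H]2C)cc2c1OC[C@@]2(C)c1ccccc1`, which differs from the others in several places, gives 4.7. Compound 4 `CNC(=O)c1cc(C(N)=O)cc2c1O[C@H](CF)[C@H]2c1ccccc1` differs from compound 1 by hydrogen in place of cyclopropyl on an amide-type nitrogen. Among the compounds with values here, no measured step swaps a cyclopropyl on an amide nitrogen for hydrogen, and the one step known concerns a different group and was small, so the measured data give no direct guide here. Resting on the structural change alone, compound 4 is expected to read lower, by an estimated a number 1.00 log units lower from compound 1 to compound 4 (beyond the scatter). The estimate for compound 4 is 2.9, with a range from 2.4 to 3.4.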

Compound 4, distribution coefficient: 2.9
Compound 4: middle estimate and measured number agree at the digits printed, within the range that was stated.
By their numbers in this assay, from the lowest: compound 4; then compounds 3 and 1 (each within the scatter of the next); then compound 2.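

In this assay, going by these compounds alone, putting hydrogen in place of cyclopropyl on the amide-type nitrogen gives a number 1.00 log units lower from compound 1 to compound 4 (beyond the scatter), the first single-place step here to clear the scatter. The other step shown, a number 0.30 log units lower from compound 1 to compound 3 (within the scatter), concerns a different group, so this amide nitrogen is the one place where a single change visibly moves the number. Nothing measured here accounts for the size of this step.

As far as these compounds go, only cyclopropyl and hydrogen are compared on this nitrogen, so it remains open where a propyl chain or a chain ending in an amine would fall.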